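Aminoalkylamino chain in place of methylpiperazine

This account rests on a few compounds, and the source may have more. Where it says the series, first, only, none or still open, it means among the compounds named here.

Compound 3 `CN1CCN(c2ccc(Cn3c(=O)[nH]c4c(N)nc(C(F)(F)F)cc43)cn2)CC1` gives 30 mL.min-1.g-1 in an in vitro ADME assay on microsomes from liver (Homo sapiens) for pharmacokinetics (a lower number here means slower removal, a higher number faster removal of the compound), the highest of the two numbers shown. Compound 1 `Nc1nc(C(F)(F)F)cc2c1[nH]c(=O)n2Cc1ccc(NCCN2CCCC2)nc1` gives 8.5 mL.min-1.g-1. Compound 2 `Nc1nc(C(F)(F)F)cc2c1[nH]c(=O)n2Cc1ccc(NCc2ccccc2)nc1` gives only a limit of the assay, < 8 mL.min-1.g-1. Compound 4 `CN(C)CCNc1ccc(Cn2c(=O)[nH]c3c(N)nc(C(F)(F)F)cc32)cn1` is not yet measured; it differs from compound 3 by (2-(dimethylamino)ethyl)amino in place of 4-methylpiperazin-1-yl on an aromatic carbon. The step that bears on this is a 3.5-fold higher number from compound 1 to compound 3 (0.55 log units; beyond the scatter), in which (2-(pyrrolidin-1-yl)ethyl)amino gave way to 4-methylpiperazin-1-yl; the present change runs the other way, returning to a chain-borne amino group. The step of an at least 3.7-fold higher number from compound 2 to compound 3 (0.57 log units; beyond the scatter) points in the same direction. A modest fall is therefore expected, a 3.3-fold lower number from compound 3 to compound 4 (0.52 log units; beyond the scatter). Compound 4 is estimated at 9 mL.min-1.g-1, with a range from 5 mL.min-1.g-1 to 18 mL.min-1.g-1.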

Compound 4, intrinsic clearance in microsomes: 9 mL.min-1.g-1
Estimate against measurement, compound 4: no gap at the digits printed; the measured number falls inside the stated range.
By their numbers in this assay, from the lowest: compounds 1 and 4 (each within the scatter of the next); then compound 3. At a limit, below all of these: compound 2.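

In this assay, (2-(dimethylamino)ethyl)amino in place of 4-methylpiperazin-1-yl gives a 3.3-fold lower number from compound 3 to compound 4 (0.52 log units; beyond the scatter), so a second chain now stands apart from the ring-bearing compound 3. Dimethylamino in place of pyrrolidin-1-yl gives a 1.1-fold higher number from compound 1 to compound 4 (0.02 log units; within the scatter), a step that lies within the scatter, so the two chains do not separate in this read-out. (Dimethylamino)methyl in place of phenyl gives an at least 1.1-fold higher number from compound 2 to compound 4 (0.05 log units; that floor lies within the scatter), and this step cannot be read, as one end of it stands only at a limit: the limit of < 8 mL.min-1.g-1 in this assay, at which 1 of the 4 values shown sits.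

Open, on these data alone, is whether the ring itself or the hydrogen-bond donor entering with the chain carries the step from compound 3. Also open, as far as these compounds go, is whether a morpholin-4-yl group or a longer chain would keep the number of compound 4.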